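The source may report more compounds than this note shows. Statements on the series, on what has been measured and on what is new or still open speak of the compounds shown alone.

Values so far in a functional assay on HeLa cells (Homo sapiens) for inhibition; on this read-out higher numbers stand for weaker inhibition and lower numbers for stronger inhibition:

- Compound 1 `Cc1ccc(C)c(C(=O)CC(SCC(=O)O)C(=O)O)c1` gives 2680 nM
- Compound 2 `Cc1ccc(C(=O)CC(SCC(=O)O)C(=O)O)cc1` gives 17300 nM

Of these two numbers, compound 2 holds the higher one, which makes it the weaker inhibitor of the pair. Compound 1 lies below it by more than the usual scatter. The two share a core and differ only in the methyl substitution on their aromatic ring.

The next compound, compound 3 `CC(C)(C)c1ccc(C(=O)CC(SCC(=O)O)C(=O)O)cc1`, keeps the core of compound 2 and changes one group: tert-butyl in place of methyl on an aromatic carbon, para to a large group (tert-butyl in place of methyl on an aromatic carbon). Going by the values given here, no measured pair isolates a change at this place, so the guidance is thin. Among the compounds with values here, the one hint is that compound 1, at 2680 nM, shows that the methyl substitution on this ring can go with a number well away from that of compound 2. A moderate step towards stronger inhibition in this assay is therefore expected, and the estimated change is a 2.9-fold lower number from compound 2 to compound 3 (0.46 log units; beyond the scatter) in this read-out. For compound 3 the expected value is 6000 nM, with an estimated range from 1500 nM to 22000 nM.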

Compound 3, half-maximal inhibitory concentration: 1390 nM
For compound 3 the middle estimate is 4.3-fold (0.64 log units) above the measured one; the whole stated range lies above it.
By their numbers in this assay, from the lowest: compounds 3 and 1 (each within the scatter of the next); then compound 2.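

Going by these compounds alone, the first measured change at this ring carbon, para to a large group, shows that the position is sensitive to what it carries: in this assay, tert-butyl in place of methyl gives a 12-fold lower number from compound 2 to compound 3 (1.10 log units; beyond the scatter) as a large step towards stronger inhibition. The earlier compounds shown here could not show this, since no measured pair isolated a change at this place. The step also shows that a group of 4 heavy atoms is accepted here in place of one of 1 heavy atom, and that this goes with a lower number, but nothing measured bears on why the number moves in this way.

A single step fixes only two points at this position, so it leaves open whether the number falls steadily from methyl through ethyl and isopropyl to tert-butyl, or whether the gain belongs to tert-butyl alone. As far as these compounds go, it is also open whether groups of another kind on the same carbon, such as a methoxy group, a chlorine atom or an amine, would move the number in the same direction.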